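The source may hold more compounds than are shown below. What is called first, only, known or untested is meant among the compounds shown, and "the series" means these compounds.

Compound 3 `O=C(CSc1nnc(-c2ccncc2)s1)Nc1ccc(Cl)cc1Cl` carries the shared core joined through a sulfur-linked acetamide to a 2,4-dichlorophenyl group. In an ADME assay on HepG2 cells (Homo sapiens) for cytotoxicity, with a stated time of 3 days (a lower number here means that less compound is tolerated, a higher number that more compound is tolerated), compound 3 gives "not determined" (no result reported), so no number of its own places it, and where it stands must be read from its two relatives. Compound 1 `CC(Sc1nnc(-c2ccncc2)s1)C(=O)Nc1ccc(Cl)cc1Cl` differs from compound 3 by one extra methyl group. In this assay compound 1 reaches only a limit, > 50000 nM. Compound 2 `CC(Sc1nnc(-c2ccncc2)s1)C(=O)Nc1ccc(Cl)cc1` is the counterpart of compound 1 with a 4-chlorophenyl group in place of the 2,4-dichlorophenyl group. In this assay compound 2 also reaches only a limit, > 50000 nM. The step that the two limits leave unreadable from compound 1 to compound 2 is therefore of unreadable size, because both ends sit at the limit of > 50000 nM in this assay, at which 2 of the 3 values shown sit.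

Compound 4 `O=C(CSc1nnc(-c2ccncc2)s1)Nc1ccc(Cl)cc1` arises from compound 3 by hydrogen in place of chloro on an aromatic carbon. This is the same change that separates compound 1 from compound 2, and that pair gave no readable step in this assay, only two limits. Nothing in the three measured compounds points to a step beyond the scatter in either direction, and both numbers that exist are limits. Compound 4 is accordingly expected to give about 60000 nM in this assay, within a range from 30000 nM to 120000 nM, most probably again reported only as a limit.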

Compound 4, half-maximal cytotoxic concentration: > 50000 nM
Compound 4 gave a limit, no number (the forecaster's own chance of this, stated with the estimate: 85%); the middle value lies beyond the limit too.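

Compound 2 and compound 4 both reach only a limit, so no new step can be read between them: the limit of > 50000 nM in this assay, at which 3 of the 4 values shown sit. The compounds shown leave open where compound 1, compound 2 and compound 4 would each give an actual number in this assay, and whether swapping hydrogen for methyl or chloro changes that number at all.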